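The source may hold more compounds than are shown below. What is called first, only, known or untested is meant among the compounds shown, and "the series" means these compounds.

Compound 3 `N#Cc1c(-c2ccc(Cl)cc2)cc(-c2ccc(Cl)cc2)n(CC(O)CCl)c1=O` gives 4.8 ug/mL in a functional assay on HepG2 cells (Homo sapiens) for cytotoxicity, read by sulforhodamine B assay, with a stated time of 48 h (on this read-out lower numbers stand for stronger inhibition and higher numbers for weaker inhibition), the lowest of the three measured numbers. Compound 1 `C#CCn1c(-c2ccc(Cl)cc2)cc(-c2ccc(Cl)cc2)c(C#N)c1=O` gives 18.3 ug/mL and compound 2 `N#Cc1c(-c2ccc(Cl)cc2)cc(-c2ccc(Cl)cc2)n([C@@H]2O[C@H](CO)[C@@H](O)[C@H](O)[C@H]2O)c1=O` gives 16.1 ug/mL in this assay; the step of a 1.1-fold lower number from compound 1 to compound 2 (0.06 log units; within the scatter) lies within the scatter, while the steps of a 3.8-fold lower number from compound 1 to compound 3 (0.58 log units; beyond the scatter) and a 3.4-fold lower number from compound 2 to compound 3 (0.53 log units; beyond the scatter) set compound 3 apart. Compound 4 `N#Cc1c(-c2ccc(Cl)cc2)cc(-c2ccc(Cl)cc2)n(C(=O)c2ccccc2)c1=O` differs from compound 3 by benzoyl in place of 3-chloro-2-hydroxypropyl on an aromatic nitrogen. Among the compounds with values here, no measured step introduces a benzoyl, so the two steps that end at compound 3 serve only as a guide: replacing its 3-chloro-2-hydroxypropyl is expected to move the number back toward those of compounds 1 and 2, a modest rise of a 2.5-fold higher number from compound 3 to compound 4 (0.40 log units; beyond the scatter). For compound 4 the estimate in this assay is 12 ug/mL, with a range from 5 ug/mL to 30 ug/mL.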

Compound 4, half-maximal inhibitory concentration: 3.75 ug/mL
For compound 4 the middle estimate is 3.2-fold (0.51 log units) above the measured one; the whole stated range lies above it.
By their numbers in this assay, from the lowest: compounds 4 and 3 (each within the scatter of the next); then compounds 2 and 1 (each within the scatter of the next).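

In this assay the low number of compound 3 does not depend on the 3-chloro-2-hydroxypropyl group: benzoyl, with its aromatic ring and no hydrogen-bond donor, gives a 1.3-fold lower number from compound 3 to compound 4 (0.11 log units; within the scatter). The gap to the other groups on this aromatic nitrogen also recurs, with a 4.3-fold lower number from compound 2 to compound 4 (0.63 log units; beyond the scatter) and a 4.9-fold lower number from compound 1 to compound 4 (0.69 log units; beyond the scatter). Two quite different groups thus share the low end of this small set, and nothing measured here explains that. Still open, from the compounds shown here alone, is whether an acetyl group, a plain butyl chain or an aminoethyl chain here would give a similar number. Also open, going by these compounds, is whether the aromatic ring of benzoyl or its carbonyl matters more.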